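The source may report more compounds than this note shows. Statements on the series, on what has been measured and on what is new or still open speak of the compounds shown alone.

Compound 1 `COc1cc(-c2ccnc3cc(-c4c[nH]c5ccccc45)nn23)cc(OC)c1OC` is the reference point of this short series. In a functional assay on HCT-116 cells (Homo sapiens) for inhibition, read by CCK-8 assay, with a stated time of 48 h (on this read-out lower numbers stand for stronger inhibition and higher numbers for weaker inhibition), compound 1 gives 35 nM, the lowest of the three numbers recorded, although compound 3 `COc1cc(-c2ccnc3cc(-c4ccc5c(ccn5C)c4)nn23)cc(OC)c1OC` with 39 nM lies within the scatter of it, so the two cannot be ordered. Compound 2 `COc1cc(-c2ccnc3cc(-c4ccc(C)c(C)c4)nn23)cc(OC)c1OC` gives 261 nM in this assay. The steps among these three are instructive: there is a 7.5-fold higher number from compound 1 to compound 2 (0.87 log units; beyond the scatter), whereas there is only a 1.1-fold higher number from compound 1 to compound 3 (0.05 log units; within the scatter); seen from the other side, there is a 6.7-fold lower number from compound 2 to compound 3 (0.83 log units; beyond the scatter). Trading the indole for a plainly substituted phenyl thus cost a modest amount, while an indole attached through its six-membered ring cost nothing.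

Compound 4 `COc1ccc(-c2cc3nccc(-c4cc(OC)c(OC)c(OC)c4)n3n2)cc1N` has not yet been measured in this assay. Relative to compound 1 the change is 3-amino-4-methoxyphenyl in place of 1H-indol-3-yl on an aromatic carbon. The step from compound 1 to compound 2 is the one that bears on this, since both changes replace the indole with a substituted phenyl; the entering group here, however, brings a hydrogen-bond donor and two acceptors rather than two methyls, so the analogy is loose. A modest rise beyond the scatter is expected for compound 4, namely a 4.3-fold higher number from compound 1 to compound 4 (0.63 log units; beyond the scatter). Compound 4 is therefore estimated at 150 nM, with a range from 50 nM to 500 nM.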

Compound 4, half-maximal inhibitory concentration: 251 nM
For compound 4 the middle estimate is 1.7-fold (0.22 log units) below the measured one; the measured number falls inside the stated range.
By their numbers in this assay, from the lowest: compounds 1 and 3 (each within the scatter of the next); then compounds 4 and 2 (each within the scatter of the next).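

In this assay a second substituted phenyl at this aromatic carbon gives a 7.2-fold higher number from compound 1 to compound 4 (0.86 log units; beyond the scatter) and likewise a 6.4-fold higher number from compound 3 to compound 4 (0.81 log units; beyond the scatter), so the loss is no longer tied to 3,4-dimethylphenyl alone. The two phenyl compounds cannot be ordered, with a 1.0-fold lower number from compound 2 to compound 4 (0.02 log units; within the scatter), which shows that 3-amino-4-methoxyphenyl, with its hydrogen-bond donor and acceptors, recovers nothing measurable over a group bearing two methyls. Among these four compounds, with no exception, the two indole-bearing compounds stand apart from the two phenyl-bearing ones, whichever way the indole is attached, and nothing shown here accounts for that split.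

The compounds shown leave open whether the split belongs to the fused two-ring shape or to the indole nitrogen, a question that a naphthyl group or a benzofuran at this carbon would bear on. They also leave open how a pyridine ring or a saturated ring such as piperidine would fall relative to the indoles and the phenyls, and whether a lone amino group or a lone methoxy on the phenyl would behave as the combined pair does.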